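This account rests on a few compounds, and the source may have more. Where it says the series, first, only, none or still open, it means among the compounds named here.

Measured so far:
Compound 1, `COc1ccc(CN2C(=O)C(=O)c3cc(-c4cccc(OC)c4)ccc32)cc1`: in a functional assay on HepG2 cells (Homo sapiens) for antiproliferative activity, read by MTT assay, with a stated time of 48 h (on this read-out higher numbers stand for weaker inhibition and lower numbers for stronger inhibition), compound 1 gives 1890 nM.
Compound 2, `COc1ccc(CN2C(=O)C(=O)c3cc(-c4ccc(F)cc4)ccc32)cc1`: in this assay compound 2 gives 3150 nM.
Compound 3, `COc1ccc(CN2C(=O)C(=O)c3cc(-c4ccc(C)cc4)ccc32)cc1`: in this assay compound 3 gives only a limit of the assay, > 10000 nM.

All three compounds share one core and differ only in the aromatic group attached to it. Compound 3 stands at the weak end of the set: its value is a limit, not a measured number, which is the situation described by the limit of > 10000 nM in this assay, at which 1 of the 3 values shown sits. The step of an at least 5.2-fold higher number from compound 1 to compound 3 (0.72 log units; beyond the scatter) and the step of an at least 3.1-fold higher number from compound 2 to compound 3 (0.50 log units; beyond the scatter) both run beyond the scatter, while a 1.7-fold higher number from compound 1 to compound 2 (0.22 log units; within the scatter) does not; compound 3 is therefore the weakest inhibitor among the three.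

Compound 4, `COc1ccc(CN2C(=O)C(=O)c3cc(-c4ccc5ccccc5c4)ccc32)cc1`, is not yet measured. It differs from compound 3 in one place: naphthalen-2-yl in place of 4-methylphenyl on an aromatic carbon. For the measured compounds named here, none of the measured steps exchanges a single ring for a fused pair of rings, so none bears directly on this change. Going by the values given here, the measured steps show only that the attached aromatic group matters and that compound 3 holds the weakest position. Compound 3 gave only a limit, > 10000 nM. The expected step of an at least 2.0-fold lower number from compound 3 to compound 4 (0.30 log units; that floor lies within the scatter) is therefore uncertain in direction as well as in size. The estimate for compound 4 in this assay is 5000 nM, with an expected range from 1500 nM to 20000 nM.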

Compound 4, half-maximal inhibitory concentration: > 10000 nM
Compound 4: only a limit was reported; the forecaster's own chance of this, stated with the estimate: 40%; at least 2.0-fold (0.30 log units) between middle value and limit.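

The fused pair of rings in naphthalen-2-yl, a shape no earlier compound carried at this position, ends where 4-methylphenyl ended in this assay, with a limit of the assay rather than a number: the limit of > 10000 nM in this assay, at which 2 of the 4 values shown sit.

Set against the two compounds that gave measured numbers, the record shows an at least 3.1-fold higher number from compound 2 to compound 4 (0.50 log units; beyond the scatter) and an at least 5.2-fold higher number from compound 1 to compound 4 (0.72 log units; beyond the scatter), so at this position on the shared core, naphthalen-2-yl goes with weaker inhibition than either 4-fluorophenyl or 3-methoxyphenyl. The step between compound 3 and compound 4 cannot be read, as both values are limits, and these two compounds therefore cannot be placed in order.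

On these data alone, what stays open is whether weak inhibition goes with carbon-only groups at the far end of the attached ring, or whether a ring carrying an amine or a carboxylic acid would give a measurable number here. As far as these compounds go, it is also open whether a methyl group moved to the position held by the methoxy of compound 1, as in 3-methylphenyl, would give a number closer to that of compound 1.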